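The source may report more compounds than this note shows. Statements on the series, on what has been measured and on what is new or still open speak of the compounds shown alone.

Measured compounds in a functional assay on MDA-MB-231 cells (Homo sapiens), read by microscopy and transwell migration, with a stated time of 24 h; a higher number here means a weaker inhibitor, a lower number a stronger inhibitor:
- compound 1, `COc1cc(-c2csc(NC(=O)c3ccccc3)n2)cc(OC)c1OC`: > 50000 nM
- compound 2, `COc1cccc(C(=O)Nc2nc(-c3cc(OC)c(OC)c(OC)c3)cs2)c1`: 14000 nM
- compound 3, `COc1cc(-c2csc(N(C)C(=O)c3cccc(OC)c3OC)n2)cc(OC)c1OC`: 108 nM

Compound 1 gives only a limit in this assay, > 50000 nM, and no number. Compound 2 gives 14000 nM. Between them lies (hydrogen in place of methoxy on an aromatic carbon), and the step of an at least 3.5-fold higher number from compound 2 to compound 1 (0.55 log units; beyond the scatter) is stated as a floor because the limit of > 50000 nM in this assay, at which 1 of the 3 values shown sits, is all that is known for compound 1. Compound 3 gives 108 nM, the lower of the two measured numbers; the difference between its core and that of compound 2 is not broken down here.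

Compound 4, `COc1ccccc1C(=O)N(C)c1nc(-c2cc(OC)c(OC)c(OC)c2)cs1`, has not yet been tested in this assay. It differs from compound 3 by hydrogen in place of methoxy on an aromatic carbon, the same kind of change as from compound 2 to compound 1, though here the site is ortho to a methoxy group (2 heavy atoms) as well as meta to a large group. The step of an at least 3.5-fold higher number from compound 2 to compound 1 (0.55 log units; beyond the scatter) suggests a loss on removing the methoxy, so a step of a 3.7-fold higher number from compound 3 to compound 4 (0.57 log units; beyond the scatter) is expected, resting on compound 3 at 108 nM. Compound 4 is estimated at 400 nM, likely between 150 nM and 1500 nM.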

Compound 4, half-maximal inhibitory concentration: > 25000 nM
Compound 4 ended at the assay's limit; the forecaster's own chance of this, stated with the estimate: 3%; at least 62-fold (1.79 log units) between middle value and limit.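

In this assay, hydrogen in place of methoxy on an aromatic carbon, which turns the 2,3-dimethoxyphenyl of compound 3 into the 2-methoxyphenyl of compound 4, gives an at least 230-fold higher number from compound 3 to compound 4 (2.36 log units; beyond the scatter) and so costs compound 3 most of its standing. As far as these compounds go, compound 4 reads > 25000 nM here, which is a limit of the assay and not a number, so this step is a floor and its true size is unknown. The change moves the number the same way on the core of compound 2 and on the core of compound 3, which is all that carries over, and the two steps cannot be set against each other in size: the same change on two cores in this assay, an at least 3.5-fold higher number (0.55 log units; beyond the scatter) from compound 2 to compound 1 and an at least 230-fold higher number (2.36 log units; beyond the scatter) from compound 3 to compound 4; the limit leaves it open whether they differ.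

The compounds shown leave open whether any other group at this site, such as a hydroxyl, a fluorine or an ethoxy, would hold the value of compound 3. Within the data shown here, they also leave open whether the methoxy matters for what it is or only for where it stands on the ring, as no compound carries it elsewhere on the core of compound 3.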